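The source may report more compounds than this note shows. Statements on the series, on what has been measured and on what is new or still open speak of the compounds shown alone.

Among the compounds with values here, compound 1 `C[C@H](c1ccc(-c2cc(Cl)ccc2-c2nc(=O)o[nH]2)cc1)N(CC1CC1)c1nc2c(C(=O)O)cccc2o1` is one of three compounds measured in a functional assay on CAL1 cells for inhibition of chemerin-like receptor 1 (Homo sapiens), with a stated time of 45 min (a higher number here means a weaker inhibitor, a lower number a stronger inhibitor), where compound 1 gives 1.3 nM. Compound 2 `CCCCN(c1nc2c(C(=O)O)cccc2o1)[C@H](C)c1ccc(-c2cc(Cl)ccc2-c2nc(=O)o[nH]2)cc1` gives 1.2 nM, and compound 3 `CCCCN(c1nc2c(C(=O)N(C)C)cccc2o1)[C@H](C)c1ccc(-c2ccccc2-c2nnn[nH]2)cc1` gives 13 nM. Compound 1 thus stands second highest of the three numbers, close to compound 2 and far from compound 3. Within the data shown here, the only measured step that changes a single place, a 1.1-fold lower number from compound 1 to compound 2 (0.03 log units; within the scatter), swapped one chain on the nitrogen for another and left the number essentially unchanged. Compound 4 `C[C@H](c1ccc(-c2cc(F)ccc2-c2nc(=O)o[nH]2)cc1)N(CC1CC1)c1nc2c(C(=O)O)cccc2o1` differs from compound 1 elsewhere: fluoro in place of chloro on an aromatic carbon. Among the measured compounds shown here, no measured step exchanges one halogen for another, so nothing measured bears directly on this change; compound 3 differs from compound 2 in several places at once, and its value shows only that larger combined changes can shift the number markedly. Exchanging one halogen for another at the same position is a small structural change, and a modest step is expected, a 1.9-fold higher number from compound 1 to compound 4 (0.28 log units; within the scatter), most likely towards a somewhat higher number. Compound 4 is therefore estimated at 2.5 nM, with a range from 0.8 nM to 8 nM.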

Compound 4, half-maximal inhibitory concentration: 2.3 nM
For compound 4 the middle estimate is 1.1-fold (0.04 log units) above the measured one, and the stated range covers the measured number.
By their numbers in this assay, from the lowest: compounds 2, 1 and 4 (each within the scatter of the next); then compound 3.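

Putting fluoro in place of chloro on this aromatic carbon gives a 1.8-fold higher number from compound 1 to compound 4 (0.25 log units; within the scatter) in this assay and is the only halogen exchange among the compounds shown. The two compounds cannot be told apart by this measurement, so at this place, meta to a large group and para to a group of 6 heavy atoms, either halogen goes with a low nanomolar number on the core of compound 1. Nothing measured here accounts for this result or links it to any property of the two halogens. The compounds shown leave open how a hydrogen, a methyl group, a methoxy group or a nitrile at this carbon would compare. They also leave open whether the same exchange would give a similar step with the chain on the nitrogen found in compound 2.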